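Notes on a phenyl to trimethoxyphenyl step, compound 2 to compound 4

The compounds below may be only part of what the source reports. "The series", "measured", "known", "first", "only" and "open" are said of these compounds alone.

Measured so far in a functional assay on MDA-MB-435 cells (Homo sapiens) for inhibition; on this read-out lower numbers stand for stronger inhibition of growth and higher numbers for weaker inhibition of growth:
- compound 1 `COc1cc(/C=C/C(=O)c2cccc(-n3cc(-c4ccc(Cl)cc4)[nH]c3=O)c2)ccc1O`: 2250 nM
- compound 2 `COc1cc(/C=C/C(=O)c2cccc(-n3cc(-c4ccccc4)[nH]c3=O)c2)cc(OC)c1OC`: 1200 nM
- compound 3 `O=C(/C=C/c1cccc(O)c1)c1cccc(-n2cc(-c3ccccc3)[nH]c2=O)c1`: 3120 nM

Compound 2 has the lowest of the three numbers in this assay. Its nearest neighbour is compound 1, whose number is higher by an amount that stays within the scatter, so no order between compound 1 and compound 2 can be read from these two values. Compound 3 is the furthest, and its gap to compound 2 lies beyond the scatter. Within the data shown here, no pair among the three differs in a single place, so no single-point step is available as a yardstick.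

Compound 4 `COc1cc(/C=C/C(=O)c2cccc(-n3cc(-c4cc(OC)c(OC)c(OC)c4)[nH]c3=O)c2)cc(OC)c1OC` is not yet measured. It differs from compound 2 by 3,4,5-trimethoxyphenyl in place of phenyl on an aromatic carbon. Among the measured compounds shown here, nothing in the measured set tells how this change behaves; the only knowledge is that compound 2 carries the lowest value. The expectation for compound 4 in this assay is a step of a 1.5-fold lower number from compound 2 to compound 4 (0.18 log units; within the scatter) toward a somewhat lower number, of a size that may well stay within the scatter. Compound 4 is estimated at 800 nM, with a range from 250 nM to 2500 nM.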

Compound 4, concentration for 50% growth inhibition: 2110 nM
For compound 4 the middle estimate is 2.6-fold (0.42 log units) below the measured one, within the range that was stated.
By their numbers in this assay, from the lowest: compounds 2, 4, 1 and 3 (each within the scatter of the next, the first and the last beyond it).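

In this assay, among these compounds, the only step between compounds that differ in one place reads a 1.8-fold higher number from compound 2 to compound 4 (0.25 log units; within the scatter) and so gives no difference that can be told from the scatter. At this aromatic carbon, 3,4,5-trimethoxyphenyl in place of phenyl adds heavy atoms to the group and brings in hydrogen-bond acceptors, yet the read-out does not separate compound 4 from compound 2. The position therefore accepts this larger group without a readable loss or gain of growth inhibition on these cells. Nothing available bears on why the two numbers lie so close.

Still open, from the compounds shown here alone, is whether an amine or a carboxylic acid at this carbon, in place of the phenyl ring, would give a step beyond the scatter. Also open, going by these compounds, is whether a single methoxy on the phenyl ring would behave as the 3,4,5-trimethoxyphenyl group does.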